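Antiproliferative Activity of Aminopyrimidine Analogues in MCF7 Cells

A few compounds are considered here, and "the series" means these few. Any claim that something is new, unique, unknown or untested is made for them only; others in the source may bear on it.

Of the compounds shown here, three have been measured in a functional assay on MCF7 cells (Homo sapiens) for antiproliferative activity, read by MTT assay, with a stated time of 72 h; on this read-out higher numbers stand for weaker inhibition of growth and lower numbers for stronger inhibition of growth. Compound 1 `Brc1cccc(Nc2nc3ncccc3n2Cc2ccccc2)c1` gives 78700 nM in this assay, compound 2 `c1ccc(Cn2c(Nc3ccccc3)nc3cccnc32)cc1` gives 51800 nM, and compound 3 `Cn1nc(-c2ccnc(Nc3cccc(O)c3)n2)c2ccccc21` gives 28200 nM. Compound 3 carries the smallest number of the three, but its gap to compound 2 lies within the usual scatter of repeated measurements, so the two cannot be told apart on these data; only compound 1 sits apart from compound 3, beyond the scatter, with the weaker inhibition of growth.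

Compound 4 `Cn1nc(-c2ccnc(Nc3ccc(Cl)cc3)n2)c2ccccc21` has not yet been measured. It differs from compound 3 in one place: 4-chlorophenyl in place of 3-hydroxyphenyl on a nitrogen on an aromatic ring. Within the data shown here, no pair of measured compounds shows this exchange, so no step can be read from the data. The remaining compounds share neither the core of compound 3 nor this exchange, and so give no guide either. In the absence of such a step, the change from compound 3 to compound 4 is expected to be small, in no fixed direction, and most likely not beyond the scatter: the step of a 1.1-fold higher number from compound 3 to compound 4 (0.03 log units; within the scatter) is the estimate. Compound 4 is therefore expected to give about 30000 nM in this assay, between 8000 nM and 100000 nM.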

Compound 4, concentration for 50% growth inhibition: 7830 nM
Compound 4: middle estimate off by 3.8-fold (0.58 log units), on the high side; the whole stated range lies above it.
By their numbers in this assay, from the lowest: compound 4; then compounds 3, 2 and 1 (each within the scatter of the next, the first and the last beyond it).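

In this assay, among these compounds, the exchange of 3-hydroxyphenyl for 4-chlorophenyl on the nitrogen on an aromatic ring gives a 3.6-fold lower number from compound 3 to compound 4 (0.56 log units; beyond the scatter), the first step in this set that can be read and one that lies beyond the scatter, so the group on this nitrogen does matter for the read-out on the shared core. The step comes with no change in the count of heavy atoms, while the hydrogen-bond donor and acceptor counted on the leaving group are absent from the entering one, and the exchange alters both the substituent and its place on the ring, so this single pair cannot separate those differences. No measured property or other outside information bears on this result, and the step therefore stands as an observation without an explanation.

From the compounds shown here alone, it remains open whether the chlorine itself or the loss of the hydroxyl carries the step, and whether the place of the substituent on the ring plays any part in it. Going by these compounds, how a plain phenyl, a methoxy group, a fluorine or an amine on this ring would compare also stays open.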